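A few compounds are considered here, and "the series" means these few. Any claim that something is new, unique, unknown or untested is made for them only; others in the source may bear on it.

Measured so far:
compound 1 `CCCCCON1C(=O)[C@@H](NC(=O)OCCCCC2CCCCC2)[C@@H]1C` — 387 nM
compound 2 `C[C@H]1[C@H](NC(=O)OCCCCC2CCCCC2)C(=O)N1OCCCS(C)(=O)=O` — 49 nM

In an assay on HEK293 cells for inhibition of N-acylethanolamine-hydrolyzing acid amidase (Homo sapiens), read by fluorescence, with stated times of 10 min and 50 min (on this read-out lower numbers stand for stronger inhibition and higher numbers for weaker inhibition), compound 1 gives 387 nM; in this assay compound 2 gives 49 nM. Within the data shown here, compound 2 therefore holds the lowest of the two numbers, and the only neighbour is compound 1, separated by a gap beyond the scatter. Among the measured compounds shown here, the single step at hand, a 7.9-fold lower number from compound 1 to compound 2 (0.90 log units; beyond the scatter), comes from methylsulfonyl in place of ethyl on a saturated chain carbon, three bonds along the chain from an oxygen on an unsaturated carbon.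

Compound 3 `C[C@H]1[C@H](NC(=O)OCCCCC2CCCCC2)C(=O)N1OCCCCC1CCCCC1` differs from compound 2 by cyclohexylmethyl in place of methylsulfonyl on a saturated chain carbon, three bonds along the chain from an oxygen; cut one bond further out the same difference reads 3-(methylsulfonyl)propyl to 4-cyclohexylbutyl. The change thus removes the very group whose entry produced the step from compound 1 to compound 2, and what enters carries no hydrogen-bond acceptors, as ethyl in compound 1. On that basis a rise in number back toward compound 1 is expected, though the seven-carbon group is larger than ethyl and the size of the rebound is uncertain. For compound 3 the estimate is 250 nM, a step of a 5.1-fold higher number from compound 2 to compound 3 (0.71 log units; beyond the scatter), with a range from 60 nM to 1000 nM.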

Compound 3, half-maximal inhibitory concentration: 3470 nM
Beside the measured number, compound 3's estimate is 14-fold (1.14 log units) below it, outside the stated range (above it).
By their numbers in this assay, from the lowest: compound 2; then compound 1; then compound 3.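

In this assay, this position is far more sensitive than the earlier pair suggested: on a saturated chain carbon, three bonds along the chain from an oxygen, cyclohexylmethyl in place of methylsulfonyl gives a 71-fold higher number from compound 2 to compound 3 (1.85 log units; beyond the scatter), a larger change than the one seen when methylsulfonyl entered. The number also does not merely return to that of the carbon-only chain of compound 1, as cyclohexyl in place of methyl, on a saturated chain carbon four bonds along the chain from an oxygen on an unsaturated carbon, gives a 9.0-fold higher number from compound 1 to compound 3 (0.95 log units; beyond the scatter), so the two carbon-only chain ends differ from each other beyond the scatter and the methylsulfonyl chain stands lowest of the three. Nothing available gives a reason for either step.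

Going by these compounds, whether the low number of compound 2 is particular to methylsulfonyl remains open, and a sulfonamide, a carboxylic acid or an amine at the same place would test this. Also open, on these data alone, is how the number follows the chain end among carbon-only groups, where a phenyl ring or a shorter chain such as propyl would give further points.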